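Widening the side chain of a bombesin receptor subtype-3 agonist

A few compounds are considered here, and "the series" means these few. Any claim that something is new, unique, unknown or untested is made for them only; others in the source may bear on it.

The series shares a biphenyl carboxylic acid linked to an imidazole and varies the group on that imidazole. In an in vitro functional assay on cells for agonist activity at Bombesin receptor subtype-3 (Mus musculus), read by luminescence and calcium flux (on this read-out lower numbers stand for an effect already at smaller amounts and higher numbers for an effect only at larger amounts of compound), compound 1 `CCCCc1cnc(C(C)Cc2ccc(-c3ccccc3C(=O)O)cc2)[nH]1` gives 184 nM, compound 2 `CCCCc1cnc(CCCc2ccc(-c3ccccc3C(=O)O)cc2)[nH]1` gives 382 nM, and compound 3 `O=C(O)c1ccccc1-c1ccc(CCc2ncc(CC3CCC3)[nH]2)cc1` gives 7.1 nM, the lowest number of the three, with both other compounds standing beyond the scatter from it. Compound 4 `COc1cccc(Cc2cnc(CCc3ccc(-c4ccccc4C(=O)O)cc3)[nH]2)c1` differs from compound 3 by 3-methoxyphenyl in place of cyclobutyl on a saturated chain carbon bound to an aromatic carbon. Going by the values given here, no measured pair shows this kind of exchange, so its effect is not known from the data. The author expects a moderate shift toward higher numbers, a 2.8-fold higher number from compound 3 to compound 4 (0.45 log units; beyond the scatter), while staying well beneath compound 1 and compound 2. For compound 4 in this assay the estimate is 20 nM, within 4 nM to 100 nM.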

Compound 4, half-maximal effective concentration: 79 nM
Estimate against measurement, compound 4: 4.0-fold (0.60 log units) below; the measured number falls inside the stated range.
By their numbers in this assay, from the lowest: compound 3; then compound 4; then compound 1; then compound 2.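

Replacing cyclobutyl with 3-methoxyphenyl on a saturated chain carbon bound to an aromatic carbon gives a large change in this assay, an 11-fold higher number from compound 3 to compound 4 (1.05 log units; beyond the scatter). Going by these compounds alone, this is the first pair differing in one place, and it shows that this position alone can move the number well beyond the scatter. No measurement among these compounds accounts for the step. The compounds shown leave open whether the change follows from the aromatic ring or from its methoxy group. An unsubstituted benzyl or a cyclohexylmethyl group at this position would separate those possibilities.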